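A few compounds are considered here, and "the series" means these few. Any claim that something is new, unique, unknown or untested is made for them only; others in the source may bear on it.

Compound 2 `C#CCSc1nc(Nc2cccc(OC)c2)c2ccncc2n1` gives 2070 nM in a functional assay on MGC-803 cells (Homo sapiens) for inhibition, read by MTT assay, with a stated time of 72 h (a higher number here means a weaker inhibitor, a lower number a stronger inhibitor), the lowest of the two numbers recorded; its nearest neighbour is compound 1 `C#CCSc1nc(Nc2ccccc2)c2ccncc2n1`, which in this assay gives 16200 nM, and the step of a 7.8-fold lower number from compound 1 to compound 2 (0.89 log units; beyond the scatter) lies beyond the scatter. Compound 3 `CCSc1nc(Nc2cccc(OC)c2)c2ccncc2n1` differs from compound 2 by methyl in place of ethynyl on a saturated chain carbon bound to a sulfur, so that the propargyl group becomes an ethyl group on the sulfur. For the measured compounds named here, the only measured step, a 7.8-fold lower number from compound 1 to compound 2 (0.89 log units; beyond the scatter), concerns the methoxy on the anilino ring and not the thioether chain, so nothing measured bears directly on the change from compound 2 to compound 3. In the absence of any step at that place, the expected change is a 1.4-fold higher number from compound 2 to compound 3 (0.16 log units; within the scatter), that is, no step beyond the scatter in either direction. Compound 3 is therefore estimated to give about 3000 nM in this assay, with a range from 900 nM to 10000 nM.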

Compound 3, half-maximal inhibitory concentration: 590 nM
For compound 3 the middle estimate is 5.1-fold (0.71 log units) above the measured one; measured number outside the range, below it.
By their numbers in this assay, from the lowest: compound 3; then compound 2; then compound 1.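

In this assay, the change from propargylsulfanyl to ethylsulfanyl gives a 3.5-fold lower number from compound 2 to compound 3 (0.55 log units; beyond the scatter), which shows that the number responds to the group on the sulfur and not only to the methoxy on an aromatic carbon. In this pair, the ethynyl is not required for the lower number, as the shorter ethyl chain with its methyl in that place gives the lower value. Nothing available explains why this change lowers the number.

The compounds shown leave open whether the same change would lower the number in the absence of the methoxy, as in compound 1. They also leave open how a longer chain such as propyl, or a chain ending in an amine or a carboxylic acid, would behave on the sulfur.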